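The source may hold more compounds than are shown below. What is called first, only, known or untested is meant among the compounds shown, and "the series" means these compounds.

In a functional assay on a cell-free system (Platelet, plasma, Homo sapiens) for inhibition, read by turbidimetry, with a stated time of 5 min (on this read-out lower numbers stand for stronger inhibition and higher numbers for weaker inhibition), compound 1 `Cc1ccc(CN2C(=O)SC[C@H]2C(=O)N2CCC[C@H](CNC(=O)OC(C)(C)C)C2)cc1` gives 10200 nM while compound 2 `Cc1ccc(CN2CSC[C@H]2C(=O)N2CCC[C@H](CNC(=O)OC(C)(C)C)C2)cc1` gives 2700 nM and so holds the lower of the two numbers, by a margin beyond the scatter. Compound 3 `Cc1ccc(CN2CSC[C@H]2C(=O)N2CCC[C@@H](CNC(=O)OC(C)(C)C)C2)cc1` has the same atoms and bonds as compound 2, the change being the two compounds have the same atoms and bonds and differ only in configuration as drawn: 1 of 2 stereo elements differ; a stereocentre at a saturated ring carbon is drawn R in compound 2 and S in compound 3 with a stereocentre at a saturated ring carbon drawn R in compound 2 and S in compound 3. For the measured compounds named here, no measured pair shows such a change, so a modest weakening is only expected, estimated as a 1.7-fold higher number from compound 2 to compound 3 (0.22 log units; within the scatter) in this assay with its direction uncertain. The estimate for compound 3 is 4500 nM with 1200 nM to 18000 nM as its expected range.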

Compound 3, half-maximal inhibitory concentration: 4700 nM
Compound 3: middle estimate off by 1.0-fold (0.02 log units), on the low side; measured number inside the range.
By their numbers in this assay, from the lowest: compounds 2 and 3 (each within the scatter of the next); then compound 1.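

In this assay, inverting the stereocentre at a saturated ring carbon gives a 1.7-fold higher number from compound 2 to compound 3 (0.24 log units; within the scatter). For the compounds shown here, this is the first reading of configuration at this position, and the two forms are not separated beyond the scatter. The comparison bears on this one stereocentre alone, because nothing else changes: the fact that compounds 2 and 3 differ only in the configuration as drawn.

The compounds shown leave open whether inverting the other stereocentre would separate the numbers. They also leave open whether this position would stay as undemanding if the tert-butyl carbamate were replaced by a free amine or a carboxylic acid.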